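This account rests on a few compounds, and the source may have more. Where it says the series, first, only, none or still open, it means among the compounds named here.

Series notes. Compound 1 `COc1ccc(CCCNCc2c(OC)cc(Oc3ccc(Nc4ccccc4)cc3)cc2OC)cc1` and compound 2 `COc1cc(Oc2cccc(Nc3ccccc3)c2)cc(OC)c1CNCc1ccc(Br)cc1` share one core and differ in the amine substituent and in where the diphenylamine-bearing ether sits. In a functional assay on DLD-1 cells (Homo sapiens) for inhibition, read by MTT assay, with a stated time of 72 h (on this read-out lower numbers stand for stronger inhibition and higher numbers for weaker inhibition), compound 1 gives 4650 nM. In this assay compound 2 gives 3520 nM. The two numbers lie within the usual scatter of each other, so compound 2 cannot be separated from compound 1 on these data; it simply stands at one end of a pair that reads as a single level.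

Compound 3 `COc1cc(Oc2cccc(Nc3ccccc3)c2)cc(OC)c1CNC1CC1` is the next member to be measured. Relative to compound 2 the change is cyclopropyl in place of 4-bromobenzyl on an amine nitrogen. Among the measured compounds shown here, no measured pair in the set isolates this kind of exchange, so there is no prior step to lean on. The expectation is a modest weakening in this assay for compound 3, a step of a 2.6-fold higher number from compound 2 to compound 3 (0.41 log units; beyond the scatter), somewhat beyond the scatter but not large. Compound 3 is accordingly expected at 9000 nM, with a range of 3000 nM to 30000 nM.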

Compound 3, half-maximal inhibitory concentration: > 20000 nM
Compound 3: only a limit was reported; the forecaster's own chance of this, stated with the estimate: 15%; middle value at least 2.2-fold (0.34 log units) away from the limit.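

In this assay compound 3 gives only a limit of the assay, > 20000 nM. Among the compounds shown here, this is the first exchange on this amine nitrogen that can be read: with cyclopropyl in place of 4-bromobenzyl, the eight heavy atoms that leave are replaced by three and the aromatic ring is lost, and the result is an at least 5.6-fold higher number from compound 2 to compound 3 (0.75 log units; beyond the scatter), which shows that this position is not indifferent to what it carries. The printed step is a floor and not a measured size, because compound 3 sits at the limit: the limit of > 20000 nM in this assay, at which 1 of the 3 values shown sits.

The pair does not tell whether the bromine, the aromatic ring or the plain count of atoms carries the difference; an unsubstituted benzyl or a straight butyl chain on the same nitrogen would begin to divide these. As far as these compounds go, compound 1 differs from compound 2 in two places and gives no second reading on this nitrogen, and how far compound 3 lies past its limit remains unknown.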